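Trading 4-Ethoxyphenyl for 3-Fluorophenyl on the Shared Core

The source may hold more compounds than are shown below. What is called first, only, known or untested is meant among the compounds shown, and "the series" means these compounds.

In a functional assay on MT4 cells (Homo sapiens) for cytotoxicity, read by MTT assay (a lower number here means that less compound is tolerated, a higher number that more compound is tolerated), compound 1 (`Cc1c(O)nc(SCc2ccc(Br)cc2)nc1Cc1c(Cl)cccc1Cl`) gives 13000 nM as its read-out. Compound 2 (`CCOc1ccc(CSc2nc(O)c(C)c(Cc3c(Cl)cccc3Cl)n2)cc1`) gives > 58000 nM in this assay and this is a limit of the assay, not a number. Compound 3 (`Cc1c(O)nc(SCc2cccc(F)c2)nc1Cc1c(Cl)cccc1Cl`) has 3-fluorophenyl in place of 4-ethoxyphenyl on a saturated chain carbon bound to a sulfur. Going by the values given here, only one measured step bears on this change. It is an at least 4.4-fold higher number from compound 1 to compound 2 (0.64 log units; beyond the scatter) with ethoxy in place of bromo on an aromatic carbon, and it lies beyond the scatter. Compound 3 drops the ethoxy group and again holds a halogen, as compound 1 does at 13000 nM in the same read-out, so part of that step is expected to be given back. Fluoro is not bromo and no measured compound carries 3-fluorophenyl, so the return is expected to be partial and the reading stays loose. The expected change is an at least 2.6-fold lower number from compound 2 to compound 3 (0.42 log units; beyond the scatter) and it is counted from a limit. Compound 3 is expected at 22000 nM within an estimated range of 8000 nM to 58000 nM in the measurement to come.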

Compound 3, half-maximal cytotoxic concentration: > 61000 nM
Compound 3 ended at the assay's limit (the forecaster's own chance of this, stated with the estimate: 25%); middle value at least 2.7-fold (0.44 log units) from the limit.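

In this assay, exchanging 4-bromophenyl for 3-fluorophenyl gives an at least 4.6-fold higher number from compound 1 to compound 3 (0.67 log units; beyond the scatter). The rise seen earlier therefore no longer belongs to 4-ethoxyphenyl alone: a phenyl that carries a halogen can also stand clear of compound 1, so holding a halogen does not by itself keep the number low. The read-out of compound 3 is a limit of the assay and not a number, so the true size of this rise remains unknown: the limit of > 61000 nM in this assay, at which 1 of the 3 values shown sits.

The step between compound 2 and compound 3 cannot be read, so it stays open which of 4-ethoxyphenyl and 3-fluorophenyl is better tolerated, with compound 2 also at a limit of the assay: the limit of > 58000 nM in this assay, at which 1 of the 3 values shown sits. The compounds shown also do not tell whether the kind of halogen or its place on the ring carries the step away from 4-bromophenyl, nor how a phenyl bearing an amine or a carboxylic acid would read at this place.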